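A few compounds are considered here, and "the series" means these few. Any claim that something is new, unique, unknown or untested is made for them only; others in the source may bear on it.

Three compounds built on the shared core of compound 1 `CS(=O)(=O)Oc1ccc(-c2cncn2C2CCN(C(=O)c3ccc(Cl)c(C(F)(F)F)c3)CC2)cc1` have been measured in an assay on HEK293 cells for antagonist activity at P2X purinoceptor 7 (Homo sapiens), read by fluorescence, with a stated time of 2 h; on this read-out higher numbers stand for weaker inhibition and lower numbers for stronger inhibition. Compound 1 gives 1570 nM. Compound 2 `O=C(c1ccc(Cl)c(C(F)(F)F)c1)N1CCC(n2cncc2-c2ccc(OS(=O)(=O)c3cccs3)cc2)CC1` gives 238 nM, and compound 3 `O=C(c1ccc(Cl)c(C(F)(F)F)c1)N1CCC(n2cncc2-c2ccc(OS(=O)(=O)c3cccc(Br)c3)cc2)CC1` gives 896 nM. Among these three numbers compound 3 stands second highest; the steps of a 1.8-fold lower number from compound 1 to compound 3 (0.24 log units; within the scatter), a 6.6-fold lower number from compound 1 to compound 2 (0.82 log units; beyond the scatter) and a 3.8-fold higher number from compound 2 to compound 3 (0.58 log units; beyond the scatter) show that only the change to thiophen-2-yl on the sulfonyl sulfur moved the number beyond the scatter, while compound 3 and compound 1 sit within it.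

Compound 4 `O=C(NC1CC1)c1cccc(S(=O)(=O)Oc2ccc(-c3cncn3C3CCN(C(=O)c4ccc(Cl)c(C(F)(F)F)c4)CC3)cc2)c1` differs from compound 3 in one place: cyclopropylcarbamoyl in place of bromo on an aromatic carbon. Going by the values given here, none of the measured steps changes a group on that six-membered aromatic ring; all of them swap the whole group on the sulfonyl sulfur. The measured steps therefore bear on this change only loosely, showing that variation around the sulfonate end of the molecule shifts this assay by modest amounts in either direction. Among the compounds with values here, with no direct precedent for cyclopropylcarbamoyl, the account expects a step for compound 4 of a 1.3-fold lower number from compound 3 to compound 4 (0.11 log units; within the scatter), that is none clearly beyond the scatter. The estimate for compound 4 in this assay is 700 nM, with a range from 200 nM to 2500 nM.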

Compound 4, half-maximal inhibitory concentration: 88 nM
For compound 4 the middle estimate is 8.0-fold (0.90 log units) above the measured one; measured number below the stated range.
By their numbers in this assay, from the lowest: compound 4; then compound 2; then compounds 3 and 1 (each within the scatter of the next).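

In this assay, going by these compounds alone, the change on the six-membered aromatic ring, meta to a large group, gives a 10-fold lower number from compound 3 to compound 4 (1.01 log units; beyond the scatter) and is the first measured step to alter a substituent on that ring rather than swap the whole group on the sulfonyl sulfur. Its result also separates 3-(cyclopropylcarbamoyl)phenyl from the other sulfonyl groups: there is a 2.7-fold lower number from compound 2 to compound 4 (0.43 log units; beyond the scatter) and an 18-fold lower number from compound 1 to compound 4 (1.25 log units; beyond the scatter) so that compound 4 has the lowest number of the four, whereas 3-bromophenyl in compound 3 stayed within the scatter of methyl in compound 1. No evidence is at hand that accounts for the size of this step.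

Cyclopropylcarbamoyl brings in the amide and the three-membered ring together, so the compounds shown cannot tell how much of the step belongs to either part, a question that an unsubstituted carboxamide, a methyl amide or a carboxylic acid in the same place would address. On these data alone, it also remains open whether cyclopropylcarbamoyl would give a similar step at another position on the ring, or whether an amine there would serve as well.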